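A few compounds are considered here, and "the series" means these few. Any claim that something is new, unique, unknown or untested is made for them only; others in the source may bear on it.

Working notes on the series. Within the data shown here, compound 1 `O=C(Nc1cc(-c2ccccc2)nn1-c1ccccc1)c1ccc(F)cc1` serves as the reference; in an assay on CHO cells with metabotropic glutamate receptor 5 (Homo sapiens) as the target (on this read-out lower numbers stand for an effect already at smaller amounts and higher numbers for an effect only at larger amounts of compound), compound 1 gives 30 nM, the lowest of the three numbers so far. Compound 3 `O=C(Nc1cc(-c2ccccc2)nn1-c1ccccc1)c1cccc(Cl)c1` gives 40 nM, and the step of a 1.3-fold higher number from compound 1 to compound 3 (0.12 log units; within the scatter) lies within the scatter. Compound 2 `O=C(Nc1cc(-c2ccccc2)nn1-c1ccccc1)c1ccccc1Cl` gives 2500 nM; the step of an 83-fold higher number from compound 1 to compound 2 (1.92 log units; beyond the scatter) is large, as is a 63-fold lower number from compound 2 to compound 3 (1.80 log units; beyond the scatter). Compound 4 `O=C(Nc1cc(-c2ccccc2)nn1-c1ccccc1)c1ccc(C(F)(F)F)cc1` differs from compound 1 by trifluoromethyl in place of fluoro on an aromatic carbon. Among the measured compounds shown here, no measured step changes the group at that place: the steps so far move a chloro between other places on the same ring and give no direct guide to a larger group para to the carbonyl. With compound 1 and compound 3 standing close and only compound 2 far off, a small change is expected: a 2.0-fold higher number from compound 1 to compound 4 (0.30 log units; within the scatter). Compound 4 is estimated at 60 nM, range 15 nM to 300 nM.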

Compound 4, half-maximal effective concentration: 19 nM
Beside the measured number, compound 4's estimate is 3.2-fold (0.50 log units) above it, and the stated range covers the measured number.
By their numbers in this assay, from the lowest: compounds 4, 1 and 3 (each within the scatter of the next, the first and the last beyond it); then compound 2.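

At this place, on an aromatic carbon para to a large group, trifluoromethyl with 4 heavy atoms stands in place of fluoro with 1, and a 1.6-fold lower number from compound 1 to compound 4 (0.20 log units; within the scatter) shows that the larger group is accepted here. Among these compounds, the step of a 2.1-fold lower number from compound 3 to compound 4 (0.32 log units; beyond the scatter) is modest but gives the first pair among the low numbers to lie beyond the scatter, while a 130-fold lower number from compound 2 to compound 4 (2.12 log units; beyond the scatter) keeps the 2-chlorophenyl compound far apart.

Going by these compounds, whether an amine, a carboxylic acid or a longer chain at this place would keep the number low stays open. Nothing at hand gives a reason for any of these steps.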